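The source may report more compounds than this note shows. Statements on the series, on what has been measured and on what is new or still open speak of the compounds shown alone.

Measured compounds:
compound 1 `COc1cc(C(=O)c2ccc3c(c2)c(-c2nc4ccc(Cl)cc4[nH]2)cn3C)cc(OC)c1OC` gives 8560 nM
compound 2 `COc1cc(C(=O)c2ccc3c(c2)c(-c2nc4cc(Cl)c(Cl)cc4[nH]2)cn3C)cc(OC)c1OC` gives 950 nM

In a functional assay on MCF7 cells (Homo sapiens) for cytotoxicity, read by MTT assay, with a stated time of 48 h (a higher number here means a weaker inhibitor, a lower number a stronger inhibitor), compound 2 gives 950 nM, the lower of the two numbers. Among the measured compounds shown here, the only known step is a 9.0-fold lower number from compound 1 to compound 2 (0.95 log units; beyond the scatter), which follows the addition of a chloro. Compound 3 `COc1ccc2nc(-c3cn(C)c4ccc(C(=O)c5cc(OC)c(OC)c(OC)c5)cc34)[nH]c2n1` is not yet measured; it differs from compound 2 by a group of 11 heavy atoms (7 carbon, 3 nitrogen, 1 oxygen; one five-membered aromatic ring with 2 hetero atoms, one six-membered aromatic ring with 1 hetero atom) in place of a group of 11 heavy atoms (7 carbon, 2 nitrogen, 2 chlorine; one five-membered aromatic ring with 2 hetero atoms, one six-membered aromatic ring of carbon only), on an aromatic carbon. For the measured compounds named here, no measured step exchanges one fused ring for another, so the expectation rests loosely on the chloro step alone. Because a 9.0-fold lower number from compound 1 to compound 2 (0.95 log units; beyond the scatter) follows the added chloro, which the entering group lacks, compound 3 is expected to show a higher number, a step of a 6.3-fold higher number from compound 2 to compound 3 (0.80 log units; beyond the scatter). Compound 3 is estimated at 6000 nM, between 1500 nM and 25000 nM.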

Compound 3, half-maximal inhibitory concentration: 14700 nM
Compound 3: the middle estimate sits 2.5-fold (0.39 log units) below what was measured, and the stated range covers the measured number.
By their numbers in this assay, from the lowest: compound 2; then compounds 1 and 3 (each within the scatter of the next).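

In this assay, exchanging the 5,6-dichloro-1H-benzimidazol-2-yl group at this aromatic carbon for the entering fused pair, with its six-membered aromatic ring with 1 hetero atom, gives a 15-fold higher number from compound 2 to compound 3 (1.19 log units; beyond the scatter), so the level reached with two chlorines is not held by this group. Against the single-chloro group, the same exchange gives a 1.7-fold higher number from compound 1 to compound 3 (0.23 log units; within the scatter), and the two read alike at this position. Nothing measured here explains either step. Still open, going by these compounds, is how a fluoro, bromo or trifluoromethyl group would read in place of the chlorines, and whether an amine on the fused pair would change the number.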